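Piperazine Amide Series: Moving to a 3-Ethoxyphenyl Group

This account rests on a few compounds, and the source may have more. Where it says the series, first, only, none or still open, it means among the compounds named here.

Measured so far:
compound 1 `COc1cccc(N2CCN(C(=O)c3oc(C)nc3-c3cccc(F)c3)CC2)c1`: "not active" (no number reported)
compound 2 `Cc1nc(-c2ccccc2)c(C(=O)N2CCN(c3cccc(C)c3C)CC2)o1`: 35 nM
compound 3 `COc1cccc(N2CCN(C(=O)c3oc(C)nc3-c3ccc(F)cc3)CC2)c1`: 112 nM

In a functional assay on HL-60 cells (Homo sapiens) for inhibition, read by MTT assay, with a stated time of 72 h (on this read-out higher numbers stand for weaker inhibition and lower numbers for stronger inhibition), compound 2 gives 35 nM, the lowest of the two numbers reported. Compound 3 gives 112 nM, a higher number that lies beyond the usual scatter, and compound 1 is reported as not active without a number. Compound 4 `CCOc1cccc(N2CCN(C(=O)c3oc(C)nc3-c3ccccc3)CC2)c1` differs from compound 2 by 3-ethoxyphenyl in place of 2,3-dimethylphenyl on an amine nitrogen in a ring. No pair of measured compounds isolates this change, so the expectation rests on the spread of the two numbers shown. The step of a 2.9-fold higher number from compound 2 to compound 4 (0.46 log units; beyond the scatter) is expected to be a moderate loss, beyond the scatter. Compound 4 is estimated at 100 nM, within a range from 30 nM to 400 nM.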

Compound 4, half-maximal inhibitory concentration: 151 nM
Estimate against measurement, compound 4: 1.5-fold (0.18 log units) below; the range from low to high includes it.
By their numbers in this assay, from the lowest: compound 2; then compounds 3 and 4 (each within the scatter of the next).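

In this assay, 3-ethoxyphenyl in place of 2,3-dimethylphenyl gives a 4.3-fold higher number from compound 2 to compound 4 (0.63 log units; beyond the scatter) and is the only step shown that isolates a change on this amine nitrogen. It shows that this position tolerates the exchange with a modest loss, while activity stays measurable. The entering group carries a hydrogen-bond acceptor that the leaving group lacks, but no available evidence connects this difference to the step. The compounds shown leave open how a longer chain such as propoxy would compare with 3-ethoxyphenyl at this position. They also leave open the result of placing an amine on this phenyl ring.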